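Lengthening the alkyl chain on the shared core

The source may report more compounds than this note shows. Statements on the series, on what has been measured and on what is new or still open speak of the compounds shown alone.

Compound 1, `CCCOc1cc(C(=O)Nc2nn[nH]n2)nc(-c2ccccc2)c1`, in a functional assay on the whole organism with Rattus norvegicus as the target, at a dose of 3 mg/kg by the oral route; a higher number here means a stronger effect of the compound at the dose given, a lower number a weaker effect: 100%
Compound 2, `CCc1cc(C(=O)Nc2nn[nH]n2)nc(-c2ccccc2)c1`, in this assay: 53%

Going by the values given here, of the two compounds measured so far, compound 2 stands lowest in this assay. Among the compounds with values here, its nearest neighbour is compound 1, and the one measured step, a number 47 percentage points lower from compound 1 to compound 2 (beyond the scatter), separates them.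

Compound 3, `CCCCc1cc(C(=O)Nc2nn[nH]n2)nc(-c2ccccc2)c1`, has not yet been measured in this assay. It differs from compound 2 in one place: ethyl in place of hydrogen on a saturated chain carbon, two bonds along the chain from an aromatic carbon.

Within the data shown here, no measured step covers the lengthening of an alkyl chain by itself; the only step on record, a number 47 percentage points lower from compound 1 to compound 2 (beyond the scatter), exchanges propoxy for ethyl and therefore bears on the change to compound 3 only indirectly. From this single step no direction can be read off with confidence, so the step from compound 2 to compound 3 is expected to stay within the scatter, a number 7 percentage points higher from compound 2 to compound 3 (within the scatter). Compound 3 is accordingly estimated at 60% in this assay, with a range from 35% to 85%.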

Compound 3, a percentage reported as inhibition, in the whole organism at one dose (the size of the read-out at that dose, not a potency): 71%
Compound 3: the middle estimate sits 11 percentage points below what was measured; the range from low to high includes it.
By their numbers in this assay, from the lowest: compound 2; then compound 3; then compound 1.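

In this assay, the step of a number 18 percentage points higher from compound 2 to compound 3 (beyond the scatter) shows that this saturated chain carbon responds to lengthening alone: ethyl in place of hydrogen there raises the effect at the dose given, whereas the earlier exchange of propoxy for ethyl altered more than the chain length. Lengthening does not close the whole gap, however, as butyl in place of propoxy on the same aromatic carbon still leaves a number 29 percentage points lower from compound 1 to compound 3 (beyond the scatter), so the propoxy compound keeps the stronger effect. No evidence is available that accounts for either step.

The compounds shown leave open whether a pentyl chain would raise the effect further or lower it. They also leave open whether an ethoxy or butoxy group in place of propoxy would keep the effect seen with compound 1.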